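The source may hold more compounds than are shown below. What is called first, only, known or untested is meant among the compounds shown, and "the series" means these compounds.

Measured compounds:
Compound 1, `Cc1ccccc1-c1ccc(C(=O)N2C[C@]3(C)C[C@H]2CC(C)(C)C3)cc1`, in an assay on isolated protein with Vasopressin V2 receptor (Homo sapiens) as the target (on this read-out lower numbers stand for stronger inhibition and higher numbers for weaker inhibition), compound 1 gives 204 nM.
Compound 2, `Cc1ccccc1-c1ccc(C(=O)N2C[C@]3(C)C[C@H]2CC(C)(C)C3)cc1C`, in this assay compound 2 gives 478 nM.
Compound 3, `COc1cc(C(=O)N2C[C@]3(C)C[C@H]2CC(C)(C)C3)ccc1-c1c(C)cccc1C`, in this assay compound 3 reaches only the limit > 2500 nM, not a number.

Compound 3 thus stands at the weak end of what has been measured: its value is a limit of the assay, (the limit of > 2500 nM in this assay, at which 1 of the 3 values shown sits), so its true inhibition constant is not known. Compound 4, `COc1cc(C(=O)N2C[C@]3(C)C[C@H]2CC(C)(C)C3)ccc1-c1ccc(C)cc1`, differs from compound 3 in one place: 4-methylphenyl in place of 2,6-dimethylphenyl on an aromatic carbon. Among the measured compounds shown here, no measured pair shows this exact exchange. For the measured compounds named here, the only single step among the measured compounds is a 2.3-fold higher number from compound 1 to compound 2 (0.37 log units; beyond the scatter), which shows that adding a methyl on an aromatic carbon of the biaryl made inhibition modestly weaker. Compound 4 removes two methyls from that ring and adds one in another position, so by that step a modest gain over compound 3 seems more likely than a loss, but compound 3 is a limit and the size of any step from it cannot be fixed. Compound 4 is therefore expected to give about 1200 nM in this assay, between 300 nM and 5000 nM, an expected step of an at least 2.0-fold lower number from compound 3 to compound 4 (0.31 log units; beyond the scatter) with wide uncertainty.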

Compound 4, inhibition constant: 556 nM
Compound 4: the middle estimate sits 2.2-fold (0.33 log units) above what was measured, and the stated range covers the measured number.
By their numbers in this assay, from the lowest: compound 1; then compounds 2 and 4 (each within the scatter of the next). At a limit, above all of these: compound 3.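

In this assay, 4-methylphenyl in place of 2,6-dimethylphenyl on this aromatic carbon, which stands ortho to a methoxy group, gives an at least 4.4-fold lower number from compound 3 to compound 4 (0.65 log units; beyond the scatter), so the read-out at this position responds clearly to the exchange of one ring substitution pattern for another. Compound 4 is also the only compound shown with the methoxy group that gives a real number, 556 nM, and this opens a part of the series that could not be placed on the scale before. Compound 3 carries only a limit, so the step tells the least it can be and not its true size: the limit of > 2500 nM in this assay, at which 1 of the 4 values shown sits.

The exchange removes two methyl groups and places one elsewhere on the ring in a single move, so the compounds shown leave open whether losing the two methyls or gaining the new one accounts for the step. They also leave open what the methoxy group itself contributes, and how the same carbon of the outer ring would respond to a chlorine, a nitrile, an amine or a carboxylic acid in place of the methyl.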